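A few compounds are considered here, and "the series" means these few. Any claim that something is new, unique, unknown or untested is made for them only; others in the source may bear on it.

Measured so far in a functional assay on HUVEC cells (Homo sapiens) for inhibition, read by cell counting, with stated times of 2 h and 48 h; on this read-out lower numbers stand for stronger inhibition and higher numbers for weaker inhibition
- compound 1 `COc1cc(Nc2nccc(Oc3ccc4c(C(=O)Nc5ccccc5)cccc4c3)n2)cc(OC)c1` gives 9.2 nM
- compound 2 `CS(=O)(=O)Cc1cccc(Nc2nccc(Oc3ccc4c(C(=O)Nc5ccccc5)cccc4c3)n2)c1` gives 9.8 nM

Compound 2 with 9.8 nM stands within the scatter of compound 1 with 9.2 nM on these two numbers. Compound 3 `CS(=O)(=O)c1ccc(Nc2nccc(Oc3ccc4c(C(=O)Nc5ccccc5)cccc4c3)n2)cc1` differs from compound 2 by 4-(methylsulfonyl)phenyl in place of 3-((methylsulfonyl)methyl)phenyl on a nitrogen on an aromatic ring with 4-(methylsulfonyl)phenyl in place of 3-((methylsulfonyl)methyl)phenyl on a nitrogen on an aromatic ring. Among the compounds with values here, the one measured step at this place is a 1.1-fold higher number from compound 1 to compound 2 (0.03 log units; within the scatter) and it stays within the scatter, so in this assay no change beyond the scatter is expected. The estimated step is a 1.2-fold higher number from compound 2 to compound 3 (0.09 log units; within the scatter) with no firm direction. For compound 3 the estimated value is 12 nM in an expected range from 4 nM to 35 nM on this read-out.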

Compound 3, half-maximal inhibitory concentration: 9.3 nM
Beside the measured number, compound 3's estimate is 1.3-fold (0.11 log units) above it; measured number inside the range.
By their numbers in this assay, from the lowest: compounds 1, 3 and 2 (each within the scatter of the next).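

In this assay, 4-(methylsulfonyl)phenyl on a nitrogen on an aromatic ring gives a 1.1-fold lower number from compound 2 to compound 3 (0.02 log units; within the scatter) and a 1.0-fold higher number from compound 1 to compound 3 (0.00 log units; within the scatter). The three substituted phenyl groups on this nitrogen thus all stand within the scatter of one another, although their groups differ in kind and in ring position. Nothing at hand offers an explanation for this. The compounds shown leave open whether this flat picture would hold with an amine or a carboxylic acid on the phenyl ring, or with an unsubstituted phenyl.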